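The compounds below may be only part of what the source reports. "The series", "measured", "known", "first", "only" and "open" are said of these compounds alone.

Compounds measured:
compound 1, `Nc1nc(-c2c(-c3ccc(F)cc3)nn3c(NC4CCCC4)cccc23)cs1` — "not determined" (no result reported) in an ADME assay on Vero cells (Chlorocebus sabaeus) for cytotoxicity; on this read-out lower numbers stand for higher toxicity in this test and higher numbers for lower toxicity in this test
compound 2, `NNc1cc(-c2c(-c3ccc(F)cc3)nn3c(NC4CCCC4)cccc23)ccn1` — 40000 nM

Among the measured compounds shown here, compound 2 holds the only number here, and compound 1 has no reported result, so nothing can be said of order between them. Compound 3, `Nc1n[nH]cc1-c1c(-c2ccc(F)cc2)nn2c(NC3CCCC3)cccc12`, differs from compound 2 by 3-amino-1H-pyrazol-4-yl in place of 2-(aminoamino)pyridin-4-yl on an aromatic carbon. For the measured compounds named here, no step between measured compounds is available to guide the estimate. The step of a 1.3-fold higher number from compound 2 to compound 3 (0.10 log units; within the scatter) is expected to be small, likely within the scatter or a modest move toward lower toxicity. Compound 3 is therefore estimated at 50000 nM in this assay, with a range from 15000 nM to 150000 nM.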

Compound 3, half-maximal cytotoxic concentration: 20000 nM
Compound 3: the middle estimate sits 2.5-fold (0.40 log units) above what was measured; low and high end bracket the measured number.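

In this assay, 3-amino-1H-pyrazol-4-yl in place of 2-(aminoamino)pyridin-4-yl on an aromatic carbon gives a 2.0-fold lower number from compound 2 to compound 3 (0.30 log units; within the scatter), so the two groups are not told apart at this position. A five-membered aromatic ring thus stands here in place of a six-membered one without a step beyond the scatter. Nothing shown accounts for this result. The step to compound 1 cannot be read, as it has no number. As far as these compounds go, whether a carboxylic acid, a morpholine or a plain phenyl at this position would move the read-out beyond the scatter remains open.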